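The compounds below may be only part of what the source reports. "The series", "measured", "known", "first", "only" and "open" are said of these compounds alone.

Measured in an assay on cells for agonist activity at probable G-protein coupled receptor 34 (Mus musculus), with a stated time of 1 h (on this read-out higher numbers stand for larger maximal responses and lower numbers for smaller maximal responses), so far:
compound 1 `N[C@@H](COP(=O)(O)OCCCOC(=O)CCc1ccccc1OCCCCCCOc1ccccc1)C(=O)O` gives 20.7%;
compound 2 `N[C@@H](COP(=O)(O)OCCCOC(=O)CCc1ccccc1OCc1cccc(Cc2ccccc2)c1)C(=O)O` gives 14.5%;
compound 3 `N[C@@H](COP(=O)(O)OCCCOC(=O)CCc1ccccc1OCc1cccc(OC2CCCCC2)c1)C(=O)O` gives 18.8%.

Compound 3 stands second of the three numbers in this assay. Its nearest neighbour is compound 1, and the gap between them lies within the scatter; its furthest is compound 2, and that gap lies within the scatter too. Among the measured compounds shown here, the only step between compounds differing in one place is a number 4.3 percentage points higher from compound 2 to compound 3 (within the scatter), so none of the three measured compounds is set apart from the others on these numbers.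

Compound 4 `N[C@@H](COP(=O)(O)OCCCOC(=O)CCc1ccccc1OCc1cccc(Oc2ccccc2Cl)c1)C(=O)O` is not yet measured. It differs from compound 3 as follows: 2-chlorophenyl in place of cyclohexyl on an oxygen on an aromatic ring.

For the measured compounds named here, the one measured step that touches this part of the structure is a number 4.3 percentage points higher from compound 2 to compound 3 (within the scatter), where a change at the same oxygen, from one six-membered ring to another, moved the number by less than the scatter. Going by the values given here, no measured pair carries a chlorine or an aromatic ring in this position, so nothing in the data points to a direction. The expectation is therefore no change beyond the scatter, a number 0.8 percentage points lower from compound 3 to compound 4 (within the scatter). Compound 4 is estimated to give 18% in this assay, within a range from 9% to 28%.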

Compound 4, largest response reached (Emax), in percent of the reference or control that the assay uses: 19.8%
Compound 4: the middle estimate sits 1.8 percentage points below what was measured; measured number inside the range.
By their numbers in this assay, from the lowest: compounds 2, 3, 4 and 1 (each within the scatter of the next).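

In this assay, among the compounds shown here, putting 2-chlorophenyl in place of cyclohexyl on an oxygen on an aromatic ring gives a number 1 percentage points higher from compound 3 to compound 4 (within the scatter), the first reading at this position of a six-membered aromatic ring of carbon only that carries a chlorine. Read with the one bond further out, 2-chlorophenoxy in place of benzyl on an aromatic carbon gives a number 5.3 percentage points higher from compound 2 to compound 4 (within the scatter), so the three groups compared at this place, benzyl, cyclohexyloxy and 2-chlorophenoxy, are not separated by this read-out. Nothing at hand bears on what lies behind these numbers.

For the compounds shown here, compound 4 is the only compound here with an aromatic ring on this oxygen, so a plain phenyl would be needed to tell the contribution of the ring from that of the chlorine. From the compounds shown here alone, whether any group at this place can move the response beyond the scatter also remains open, for instance an amine or a carboxylic acid on the ring, or a longer chain on the oxygen in place of the ring.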